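The source may hold more compounds than are shown below. What is called first, only, known or untested is meant among the compounds shown, and "the series" means these compounds.

Working notes on the series built on the shared core of compound 3 `CNCc1ccc(Cl)c(-c2ccccc2OC)c1`. In an assay on isolated protein for binding affinity to 5-hydroxytryptamine receptor 3A (Homo sapiens) (a lower number here means a stronger inhibitor, a higher number a weaker inhibitor), compound 3 gives only a limit, > 10000 nM. Compound 2 `COc1ccccc1-c1cc(C2CCN(C)C2)ccc1Cl` gives in this assay a numbered value, 420 nM. Compound 1 `CCCN(CCC)Cc1ccc(Cl)c(-c2ccccc2OC)c1` gives in this assay a limit as well, > 10000 nM. The limit of > 10000 nM in this assay, at which 2 of the 3 values shown sit, thus holds two of the three measured compounds.

Compound 4 `CCNCc1ccc(Cl)c(-c2ccccc2OC)c1` differs from compound 3 by methyl in place of hydrogen on a saturated chain carbon bound to an amine nitrogen. Among the measured compounds shown here, two measured steps bear on this change. For the measured compounds named here, the step of an at least 23-fold higher number from compound 2 to compound 3 (1.37 log units; beyond the scatter) sets the distance between the one numbered value and the limit at which compound 3 sits. The step that the two limits leave unreadable from compound 1 to compound 3 cannot be sized, yet compound 1 with dipropylamino on the same carbon sits at the limit just as compound 3 does with methylamino, and the ethylamino group of compound 4 stands between these two groups. Compound 4 is therefore expected to remain at the limit, the step that the limit leaves unreadable from compound 3 to compound 4 being the estimate. In this assay compound 4 is expected at 15000 nM, within a range from 5000 nM to 50000 nM.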

Compound 4, inhibition constant: > 10000 nM
Compound 4 was reported as a limit (the forecaster's own chance of this, stated with the estimate: 80%); the middle value lies beyond the limit too.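

Replacing 1-methylpyrrolidin-3-yl with (ethylamino)methyl on the aromatic carbon gives an at least 23-fold higher number from compound 2 to compound 4 (1.37 log units; beyond the scatter), so the ethylamino group does not recover the numbered value of compound 2 in this assay. The steps among compound 1, compound 3 and compound 4 cannot be read, so any effect of methyl in place of hydrogen on the saturated chain carbon stays hidden behind the limit. The series now has one numbered value, and the other compounds share a single limit: the limit of > 10000 nM in this assay, at which 3 of the 4 values shown sit.

Still open, on these data alone, is whether dimethylamino or a primary amine on the same carbon would give a numbered value in this assay. Also open, as far as these compounds go, is how far compound 4 and compound 3 lie beyond the limit, and so whether the ethylamino group changes the value at all.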